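Compound 3 to compound 4: dipropylamino for diethylamino

The compounds below may be only part of what the source reports. "The series", "measured", "known", "first", "only" and "open" are said of these compounds alone.

In a functional assay on PC-3 cells (Homo sapiens) for antiproliferative activity, read by WST assay, with a stated time of 3 days (a lower number here means a stronger inhibitor, a higher number a weaker inhibitor), compound 1 `CCCCCCOc1c(-c2cc(OC)c(OC)c(OC)c2)oc2ccccc2c1=O` gives 29200 nM and compound 2 `CCCC(C)Oc1c(-c2cc(OC)c(OC)c(OC)c2)oc2ccccc2c1=O` gives 49300 nM while compound 3 `CCN(CC)CCCCOc1c(-c2cc(OC)c(OC)c(OC)c2)oc2ccccc2c1=O` gives 13700 nM as the lowest of the three numbers. Compound 4 `CCCN(CCC)CCCCOc1c(-c2cc(OC)c(OC)c(OC)c2)oc2ccccc2c1=O` is still unmeasured and differs from compound 3 in one place (dipropylamino in place of diethylamino on a saturated chain carbon, four bonds along the chain from an oxygen on an aromatic ring), on a saturated chain carbon, four bonds along the chain from an oxygen on an aromatic ring.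

Two measured steps bring in the diethylamino group, and both are modest (a 2.1-fold lower number from compound 1 to compound 3 (0.33 log units; beyond the scatter); a 3.6-fold lower number from compound 2 to compound 3 (0.56 log units; beyond the scatter)). The step between the two compounds without that group stays within the scatter (a 1.7-fold higher number from compound 1 to compound 2 (0.23 log units; within the scatter)). Among the compounds with values here, none of these steps alters the groups on the nitrogen, so the data hold no direct precedent for this change. Even exchanging the whole group on the oxygen moved the number only modestly (a 3.6-fold lower number from compound 2 to compound 3 (0.56 log units; beyond the scatter)), so for this smaller exchange no step beyond the scatter is expected in this assay in either direction.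

The expected step is a 1.1-fold lower number from compound 3 to compound 4 (0.06 log units; within the scatter) and no more than that is anticipated. For compound 4 the estimated value is 12000 nM with an expected range from 5500 nM to 26000 nM in this measurement.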

Compound 4, half-maximal inhibitory concentration: 11600 nM
Beside the measured number, compound 4's estimate is 1.0-fold (0.01 log units) above it, within the range that was stated.
By their numbers in this assay, from the lowest: compounds 4 and 3 (each within the scatter of the next); then compounds 1 and 2 (each within the scatter of the next).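

In this assay, the first change made to the groups on the nitrogen gives a 1.2-fold lower number from compound 3 to compound 4 (0.07 log units; within the scatter), so at this place, on a saturated chain carbon, four bonds along the chain from an oxygen on an aromatic ring, exchanging diethylamino for dipropylamino leaves the number unchanged within the scatter. The modest steps seen earlier on bringing in diethylamino recur with dipropylamino, as a 2.5-fold lower number from compound 1 to compound 4 (0.40 log units; beyond the scatter) and a 4.3-fold lower number from compound 2 to compound 4 (0.63 log units; beyond the scatter), so among these compounds they do not depend on which of the two amines is present. Nothing available bears on the reason for this result.

The compounds shown leave open whether dimethylamino, or a ring amine such as piperidinyl or morpholinyl, on the same chain would give a number in line with those of compound 3 and compound 4. They also leave open how a shorter or longer chain would carry the amine, and whether a carboxylic acid at the end of the chain would keep the modest steps seen with the two amines.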